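The compounds below may be only part of what the source reports. "The series", "measured", "known", "first", "only" and "open" are said of these compounds alone.

Measured compounds in a functional assay on HCT-15 cells (Homo sapiens) for inhibition, read by sulforhodamine B assay, with a stated time of 48 h; on this read-out higher numbers stand for weaker inhibition of growth and lower numbers for stronger inhibition of growth:

- compound 1 `CCOC(=O)[C@H](CCC(=O)O)NC(=O)c1ccc(Sc2nc3cc(N)cc(N)c3nc2-c2ccccc2)cc1`: compound 1 gives 13500 nM
- compound 2 `Nc1cc(N)c2nc(-c3ccccc3)c(Sc3ccc(F)cc3)nc2c1`: compound 2 gives 13500 nM
- compound 3 `COc1cc(CNc2nc3cc(N)cc(N)c3nc2-c2ccccc2)cc(OC)c1OC`: compound 3 gives 3240 nM

On these numbers compound 2 stands level with compound 1 at the digits shown, the two together being the highest of the three values in this assay, and the gap between them lies within the scatter. Compound 3 is the furthest from compound 2, with a lower number that lies beyond the scatter.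

The piece follows the step from compound 2 to compound 4 `Nc1cc(N)c2nc(-c3ccccc3)c(NCc3ccc(F)cc3)nc2c1`, which has not yet been measured in this assay. The change is (4-fluorobenzyl)amino in place of (4-fluorophenyl)sulfanyl on an aromatic carbon. Among the compounds with values here, no single-change step between measured compounds is known here, so the expected size rests only on the spread of the three values. Given that compound 3, which also carries a benzylamino group on the shared core, gives 3240 nM, a modest move towards a lower number is expected, of roughly a 2.3-fold lower number from compound 2 to compound 4 (0.35 log units; beyond the scatter). Compound 4 is therefore estimated at 6000 nM, within a range from 2000 nM to 20000 nM.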

Compound 4, concentration for 50% growth inhibition: 3310 nM
For compound 4 the middle estimate is 1.8-fold (0.26 log units) above the measured one; the measured number falls inside the stated range.
By their numbers in this assay, from the lowest: compounds 3 and 4 (each within the scatter of the next); then compounds 1 and 2 (each within the scatter of the next).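

In this assay, the change at this position, on the aromatic carbon next to the ring nitrogen, gives a 4.1-fold lower number from compound 2 to compound 4 (0.61 log units; beyond the scatter), the first single-place step shown, so what this carbon carries does affect the read-out. The step changes more than one thing at once: (4-fluorobenzyl)amino has nitrogen where (4-fluorophenyl)sulfanyl has sulfur, one more carbon and a hydrogen-bond donor, and this step alone cannot separate these changes. Nothing measured here explains the shift.

The compounds shown leave open how a (4-fluorophenyl)amino or a (4-fluorobenzyl)sulfanyl group would stand here, which would part the linking atom from the added carbon. Compound 3 at 3240 nM and compound 4 at 3310 nM lie within the scatter of each other, and an unsubstituted benzylamino group remains an open case.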